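Notes on the bromo to methoxy step

The compounds below may be only part of what the source reports. "The series", "measured", "known", "first", "only" and "open" are said of these compounds alone.

Compound 1 `COc1cc2oc(-c3cccc(NC(=O)c4cccc(Br)c4)c3)cc(=O)c2c(OC)c1OC` gives 6340 nM
Compound 2 `COc1cccc(C(=O)Nc2cccc(-c3cc(=O)c4c(OC)c(OC)c(OC)cc4o3)c2)c1` gives 7670 nM
Compound 3 `COc1cc2oc(-c3cccc(NC(=O)c4cccc(Br)c4)c3)cc(=O)c2c(O)c1OC` gives 6940 nM

All three numbers come from a functional assay on MCF7 cells (Homo sapiens) for inhibition, read by MTT assay (on this read-out lower numbers stand for stronger inhibition of growth and higher numbers for weaker inhibition of growth), and lie within the scatter of each other, compound 3 at 6940 nM included, so no order can be read among them. Compound 4 `COc1cccc(C(=O)Nc2cccc(-c3cc(=O)c4c(O)c(OC)c(OC)cc4o3)c2)c1` is still unmeasured. Its difference from compound 3 is methoxy in place of bromo on an aromatic carbon and amounts to methoxy in place of bromo on an aromatic carbon, meta to a large group.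

The same exchange has one measured precedent, a 1.2-fold higher number from compound 1 to compound 2 (0.08 log units; within the scatter) on a compound that keeps methyl on the oxygen where compound 3 has hydrogen. The other measured step, a 1.1-fold higher number from compound 1 to compound 3 (0.04 log units; within the scatter) for hydrogen in place of methyl on an oxygen on an aromatic ring, leads to the background on which the new exchange is made. Within the data shown here, neither step leaves the scatter, and the two changes have not yet been seen together in a measured compound. No step beyond the scatter is therefore expected in this assay for this exchange. The expected step is a 1.2-fold higher number from compound 3 to compound 4 (0.06 log units; within the scatter) by this estimate. For compound 4 the estimated value is 8000 nM with an expected range from 5000 nM to 12500 nM in this series.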

Compound 4, concentration for 50% growth inhibition: 35600 nM
For compound 4 the middle estimate is 4.5-fold (0.65 log units) below the measured one; the measured number lies above the stated range.
By their numbers in this assay, from the lowest: compounds 1, 3 and 2 (each within the scatter of the next); then compound 4.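

In this assay, the exchange of 3-bromophenyl for 3-methoxyphenyl depends on what sits on the core oxygen: with hydrogen there it gives a 5.1-fold higher number from compound 3 to compound 4 (0.71 log units; beyond the scatter), whereas with methyl there it stayed within the scatter, a gap that is itself larger than the scatter allows: the same change on two cores in this assay, a 1.2-fold higher number (0.08 log units; within the scatter) from compound 1 to compound 2 and a 5.1-fold higher number (0.71 log units; beyond the scatter) from compound 3 to compound 4, 4.2-fold (0.63 log units) apart, beyond the scatter of two such steps. Read the other way, hydrogen in place of methyl on that oxygen gives a 4.6-fold higher number from compound 2 to compound 4 (0.67 log units; beyond the scatter) when methoxy is on the benzoyl ring, although the same change stayed within the scatter with bromo there: the same change on two cores in this assay, a 1.1-fold higher number (0.04 log units; within the scatter) from compound 1 to compound 3 and a 4.6-fold higher number (0.67 log units; beyond the scatter) from compound 2 to compound 4, 4.2-fold (0.63 log units) apart, beyond the scatter of two such steps. The two changes therefore do not simply add: compounds 1, 2 and 3 cannot be ordered among themselves, and the weaker inhibition of growth appears only in compound 4, where methoxy and the oxygen-bound hydrogen occur together.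

From the compounds shown here alone, whether this loss is particular to methoxy or also appears with a chloro group, an amine or a carboxylic acid at the same place on the hydrogen-bearing core stays open. The four compounds include no measured property that would explain the interaction, and one cell assay cannot show whether it holds elsewhere.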